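Alkoxy chain length and anilide change in a cyclic nucleotide phosphodiesterase series

A few compounds are considered here, and "the series" means these few. Any claim that something is new, unique, unknown or untested is made for them only; others in the source may bear on it.

Measured so far:
compound 1 `COc1nc2c(c(=O)n(C)c(=O)n2C)n1CCCC(=O)Nc1ccc(C(C)C)cc1` — > 200000 nM
compound 2 `CCOc1nc2c(c(=O)n(C)c(=O)n2C)n1CCCC(=O)Nc1ccc(C(C)C)cc1` — 96300 nM
compound 3 `CCCOc1nc2c(c(=O)n(C)c(=O)n2C)n1CCCC(=O)Nc1ccc(C(C)C)cc1` — 37600 nM

In an assay on isolated protein for inhibition of high affinity 3',5'-cyclic-AMP phosphodiesterase 7A (Homo sapiens), read by cAMP accumulation, with a stated time of 10 min (a lower number here means a stronger inhibitor, a higher number a weaker inhibitor), compound 1 reaches only the limit of the assay, > 200000 nM, and not a number. Compound 2 gives 96300 nM and compound 3 gives 37600 nM, the lowest of the two numbers in this assay. The steps run in one direction: an at least 2.0-fold lower number from compound 1 to compound 2 (0.31 log units; beyond the scatter), an at least 5.3-fold lower number from compound 1 to compound 3 (0.72 log units; beyond the scatter) and a 2.6-fold lower number from compound 2 to compound 3 (0.41 log units; beyond the scatter), all beyond the scatter.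

Compound 4 `CCCOc1nc2c(c(=O)n(C)c(=O)n2C)n1CCCC(=O)Nc1cc(C(C)(C)C)ccc1O` differs from compound 3 at the anilide: 2-hydroxy-5-(tert-butyl)phenyl in place of 4-isopropylphenyl on an amide-type nitrogen. Going by the values given here, none of the measured steps touches this part of the molecule; all three concern the saturated chain on the aromatic oxygen. The measured steps therefore give no direct guide to the size or direction of the step to compound 4, and the expectation rests on the structural change alone, with wide uncertainty.

Compound 4 is expected to give 15000 nM in this assay, within 2000 nM to 100000 nM. The expected step is a 2.5-fold lower number from compound 3 to compound 4 (0.40 log units; beyond the scatter), which may fall inside the scatter.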

Compound 4, half-maximal inhibitory concentration: 41200 nM
For compound 4 the middle estimate is 2.7-fold (0.44 log units) below the measured one; low and high end bracket the measured number.
By their numbers in this assay, from the lowest: compounds 3 and 4 (each within the scatter of the next); then compound 2. At a limit, above all of these: compound 1.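

In this assay, going by these compounds alone, the anilide on the amide-type nitrogen is varied for the first time, and 2-hydroxy-5-(tert-butyl)phenyl in place of 4-isopropylphenyl gives a 1.1-fold higher number from compound 3 to compound 4 (0.04 log units; within the scatter) and leaves the two compounds indistinguishable. The three earlier steps, all on the saturated chain on the aromatic oxygen, each lay beyond the scatter, whereas this exchange of a larger aryl group carrying a hydrogen-bond donor and acceptor does not, so this position accepts that change with no measurable difference in the number. The data shown give no reason why the number stays level here.

Within the data shown here, the exchange alters the hydroxy group and the alkyl group in one step, so the part each plays at the anilide remains unresolved, and a compound with only one of the two changes would be needed to separate them. Also open, on these data alone, are whether an amine or a carboxylic acid on the anilide ring would move the number beyond the scatter, and whether a butyl chain on the aromatic oxygen would extend the trend seen from compound 2 to compound 3.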